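Compound 3: furan-2-yl replaces the 3,4-dimethoxyphenyl group

A few compounds are considered here, and "the series" means these few. Any claim that something is new, unique, unknown or untested is made for them only; others in the source may bear on it.

Measured in a functional assay on THP-1 cells (Homo sapiens) for cytotoxicity, read by sulforhodamine B assay, with a stated time of 48 h; on this read-out lower numbers stand for stronger inhibition and higher numbers for weaker inhibition:
- compound 1 `COc1cc(/C=C/C(=O)/C=C/c2cc(OC)c(OC)c(OC)c2)ccc1OCc1cn(CCOc2cc(=O)oc3ccccc23)nn1`: 820 nM
- compound 2 `COc1ccc(/C=C/C(=O)/C=C/c2ccc(OCc3cn(CCOc4cc(=O)oc5ccccc45)nn3)c(OC)c2)cc1OC`: 2340 nM

Compound 2 has the higher of the two numbers, so it is the weaker inhibitor of the pair. Compound 3 `COc1cc(/C=C/C(=O)/C=C/c2ccco2)ccc1OCc1cn(CCOc2cc(=O)oc3ccccc23)nn1` carries furan-2-yl in place of 3,4-dimethoxyphenyl on a double-bonded chain carbon bound to a double-bonded chain carbon. For the measured compounds named here, one measured step bears on this group: a 2.9-fold higher number from compound 1 to compound 2 (0.46 log units; beyond the scatter), a modest change made by putting hydrogen in place of methoxy on the same ring. A single step is thin evidence, but in this assay a further modest rise is expected. The expected step is a 1.5-fold higher number from compound 2 to compound 3 (0.17 log units; within the scatter). For compound 3 the estimated value is 3500 nM, with an expected range of 1200 nM to 10000 nM.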

Compound 3, half-maximal inhibitory concentration: 7870 nM
The estimate for compound 3 lay 2.2-fold (0.35 log units) below the measured number; the range from low to high includes it.
By their numbers in this assay, from the lowest: compound 1; then compound 2; then compound 3.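

Replacing 3,4-dimethoxyphenyl with furan-2-yl in this assay gives a 3.4-fold higher number from compound 2 to compound 3 (0.53 log units; beyond the scatter) and replacing 3,4,5-trimethoxyphenyl with furan-2-yl gives a 9.6-fold higher number from compound 1 to compound 3 (0.98 log units; beyond the scatter) at the same place. This position therefore responds not only to the loss of one methoxy but also to an exchange of the whole aromatic ring, and the number rises in all three compounds as methoxy groups leave this ring. No measurement shown explains the rise. Still open, from the compounds shown here alone, is whether a plain phenyl ring would behave like the furan-2-yl group. Going by these compounds, the effect of a pyridine ring or an amine here also remains unknown.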